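The source may report more compounds than this note shows. Statements on the series, on what has been measured and on what is new or still open speak of the compounds shown alone.

Compound 1 `O=C(COc1ccc(C(=O)/C=C/c2ccccc2Cl)cc1)N[C@H]1CCOC1=O` is the one compound in a functional assay on DU-145 cells (Homo sapiens) for antiproliferative activity, read by MTT assay, with a stated time of 72 h (on this read-out higher numbers stand for weaker inhibition and lower numbers for stronger inhibition), for which a number rather than a limit is shown: compound 1 gives 3240 nM. Compound 2 `O=C(CNc1ccccc1Cl)N[C@H]1CCOC1=O` reaches only the limit of this assay, > 64000 nM. Compound 3 `O=C(CNc1cccc(Cl)c1)N[C@H]1CCOC1=O` likewise reaches only the limit, > 64000 nM. Two of the three values therefore sit at the limit of > 64000 nM in this assay, at which 2 of the 3 values shown sit. Among the measured compounds shown here, compound 1 thus stands alone as the single measured number, and no step between measured compounds can be counted. Compound 4 `O=C(COc1ccc(C(=O)/C=C/c2ccc(F)cc2)cc1)N[C@H]1CCOC1=O` differs from compound 1 in one place: 4-fluorophenyl in place of 2-chlorophenyl on a double-bonded chain carbon bound to a double-bonded chain carbon. For the measured compounds named here, with no measured step to lean on, the step from compound 1 to compound 4 in this assay is expected to be small, estimated at a 1.2-fold higher number from compound 1 to compound 4 (0.09 log units; within the scatter), a change not clearly beyond the usual scatter in either direction. Compound 4 is therefore expected to give about 4000 nM in this assay, with an estimated range from 1500 nM to 12000 nM.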

Compound 4, half-maximal inhibitory concentration: 18800 nM
For compound 4 the middle estimate is 4.7-fold (0.67 log units) below the measured one, outside the stated range (above it).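

In this assay the place on a double-bonded chain carbon bound to a double-bonded chain carbon proves sensitive to the group it carries: 4-fluorophenyl in place of 2-chlorophenyl gives a 5.8-fold higher number from compound 1 to compound 4 (0.76 log units; beyond the scatter), even though both groups have the same count of heavy atoms and the same aromatic ring. Among the compounds shown here, this is the first step that can be read at all, and it runs toward weaker inhibition, while compound 4 still gives a number rather than a limit. Nothing measured here on either group accounts for the step.

The halogen and its place on the ring change at once, and the compounds shown do not separate the two. Going by these compounds, how 4-chlorophenyl, 2-fluorophenyl or a phenyl ring carrying an amine or a carboxylic acid would read at this place remains open.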